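The source may hold more compounds than are shown below. What is called first, only, known or untested is meant among the compounds shown, and "the series" means these compounds.

Compound 1 `CC1CCN(C2CCN(S(=O)(=O)c3cccc(N)c3)CC2)CC1` gives 3400 nM in a functional assay on DLD-1 cells (Homo sapiens) for antiproliferative activity, read by CellTiter-Glo, with a stated time of 72 h; a lower number here means a stronger inhibitor, a higher number a weaker inhibitor.
Compound 2 `CCc1ccc(S(=O)(=O)N2CCC(N3CCC(C)CC3)CC2)cc1` gives > 5000 nM in this assay, which is a limit of the assay and not a number.

For the measured compounds named here, compound 1 holds the only number so far; the other value is a limit. Going by the values given here, the one measured step, 4-ethylphenyl in place of 3-aminophenyl on a sulfonyl sulfur, reads an at least 1.4-fold higher number from compound 1 to compound 2 (0.16 log units; that floor lies within the scatter), and it ends at a limit (the limit of > 5000 nM in this assay, at which 1 of the 2 values shown sits).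

Compound 3 `CC1CCN(C2CCN(S(=O)(=O)c3cccc(-c4ccccc4C(F)(F)F)c3)CC2)CC1` differs from compound 1 by 2-(trifluoromethyl)phenyl in place of amino on an aromatic carbon. This step bears some likeness to the measured one, since both remove the amino, and that measured step gave no stronger inhibitor. Compound 3 is therefore expected to give 5000 nM in this assay, with a range from 1500 nM to 15000 nM. The expected step is a 1.5-fold higher number from compound 1 to compound 3 (0.17 log units; within the scatter), weaker or within the scatter, and a limit rather than a number is a real possibility for compound 3.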

Compound 3, half-maximal inhibitory concentration: 10 nM
The estimate for compound 3 lay 500-fold (2.70 log units) above the measured number; measured number below the stated range.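

In this assay, 2-(trifluoromethyl)phenyl in place of amino on an aromatic carbon gives a 340-fold lower number from compound 1 to compound 3 (2.53 log units; beyond the scatter). This position, meta to a large group, therefore does not depend on the amino for activity in this series, and it accepts a much larger aromatic group with a marked gain. The earlier step could not show this, since compound 2 carries a limit of the assay and not a number, which leaves that step without a measured size: the limit of > 5000 nM in this assay, at which 1 of the 3 values shown sits.

Open, going by these compounds, is how much of the step belongs to the added ring and how much to the trifluoromethyl on it; an unsubstituted phenyl, or a methyl or methoxy in place of the trifluoromethyl, would separate the two. Also open, on these data alone, is whether the step carries over when a different amine replaces the one in the shared core.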